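Huh-7 growth inhibition: benzyl ether in place of aryl ketone

The compounds below may be only part of what the source reports. "The series", "measured", "known", "first", "only" and "open" are said of these compounds alone.

Compounds measured so far:
compound 1 `COc1cc2c(=O)c(C(=O)c3ccc(C)cc3)cn(Cc3ccc(Cl)cc3)c2cc1OC` gives 15500 nM in an ADME assay on Huh-7 cells (Homo sapiens) for cytotoxicity; a lower number here means a stronger inhibitor of growth, a higher number a weaker inhibitor of growth
compound 2 `COc1cc2c(=O)c(C(=O)c3ccc(C)cc3)cn(Cc3ccc(C(F)(F)F)cc3F)c2cc1OC` shows only a limit, > 25000 nM, in this assay
compound 3 `COc1cc2c(=O)c(C(=O)c3ccc(C)cc3)cn(Cc3ccccc3)c2cc1OC` is recorded as "not active" (no number reported) in this assay

Compound 3 thus stands without a number in this assay; it is simply recorded as inactive. Of compound 2 only the limit of > 25000 nM in this assay, at which 1 of the 3 values shown sits, is known. For the measured compounds named here, the only measured step, an at least 1.6-fold higher number from compound 1 to compound 2 (0.20 log units; that floor lies within the scatter), concerns the group on the saturated chain carbon bound to the aromatic nitrogen and does not touch the position changed here.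

Compound 4 `COc1cc2c(=O)c(COCc3ccc(Cl)cc3)cn(Cc3ccccc3)c2cc1OC` differs from compound 3 by ((4-chlorobenzyl)oxy)methyl in place of (4-methylphenyl)carbonyl on an aromatic carbon

Going by the values given here, no measured step bears on this change, and with compound 3 inactive, no shift beyond the scatter is expected; a weak or absent effect is anticipated. Compound 4 is therefore expected at about 25000 nM, estimated within 10000 nM to 80000 nM.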

Compound 4, concentration for 50% growth inhibition: "not active" (no number reported)
For compound 4 the study gives words and no number, and the estimate cannot be compared.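

Compound 3 and compound 4 are both recorded only as not active in this assay, so no step can be read between them, and nothing measured bears on this result. On these data alone, how ((4-chlorobenzyl)oxy)methyl in place of (4-methylphenyl)carbonyl acts alongside a group other than the benzyl group stays open.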